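The compounds below may be only part of what the source reports. "The series", "measured", "known", "first", "only" and "open" are said of these compounds alone.

Measured so far:
compound 1 `O=c1oc(CO)cc2ccccc12` — 89.3 ug/mL
compound 2 `COc1ccc2cc(CO)oc(=O)c2c1` — 32.6 ug/mL

Compound 2 stands lowest of the two numbers measured in a functional assay on MCF7 cells (Homo sapiens) for antiproliferative activity, read by sulforhodamine B assay, with a stated time of 48 h; a lower number here means a stronger inhibitor of growth, a higher number a weaker inhibitor of growth; its nearest neighbour is compound 1, and the difference a 2.7-fold lower number from compound 1 to compound 2 (0.44 log units; beyond the scatter) lies beyond the scatter. Compound 3 `COc1ccc2cc(CCCO)oc(=O)c2c1` differs from compound 2 by 2-hydroxyethyl in place of hydroxy on a saturated chain carbon bound to an aromatic carbon: the same difference, cut one bond further out, reads hydroxymethyl to 3-hydroxypropyl. Among the compounds with values here, the only measured step, a 2.7-fold lower number from compound 1 to compound 2 (0.44 log units; beyond the scatter), concerns a methoxy replacing hydrogen on an aromatic carbon and says nothing about the length of the hydroxy-bearing chain; no measured pair bears on the change from compound 2 to compound 3. With no guidance from the data, the expectation for compound 3 in this assay is a step of a 1.2-fold lower number from compound 2 to compound 3 (0.07 log units; within the scatter), not beyond the scatter. Compound 3 is therefore estimated at 28 ug/mL, with a range from 9 ug/mL to 85 ug/mL.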

Compound 3, concentration for 50% growth inhibition: 25.8 ug/mL
Compound 3: middle estimate off by 1.1-fold (0.04 log units), on the high side, within the range that was stated.
By their numbers in this assay, from the lowest: compounds 3 and 2 (each within the scatter of the next); then compound 1.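

At the saturated chain carbon bound to an aromatic carbon, 2-hydroxyethyl in place of hydroxy, which reads as hydroxymethyl to 3-hydroxypropyl, gives a 1.3-fold lower number from compound 2 to compound 3 (0.10 log units; within the scatter) in this assay. With the methoxy in place, this position therefore accepts the longer hydroxy-bearing chain without a step beyond the scatter, a reading the earlier step, which concerned only the methoxy, could not give. Nothing on hand bears on why compound 2 and compound 3 read alike.

Still open, on these data alone, is whether the terminal hydroxy is needed at all, which an amine or a carboxylic acid in its place on the 3-hydroxypropyl chain would test, and whether a longer chain reads the same. Also open, as far as these compounds go, is whether the same extension on the core of compound 1, without the methoxy, gives a similar step.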